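Trading an aromatic arm for an open hydroxy chain

A few compounds are considered here, and "the series" means these few. Any claim that something is new, unique, unknown or untested is made for them only; others in the source may bear on it.

Measured in an ADME assay on A549 cells (Homo sapiens) for cytotoxicity, read by resazurin assay, with a stated time of 48 h; on this read-out higher numbers stand for lower toxicity in this test and lower numbers for higher toxicity in this test:
- Compound 1 `O=C(Nc1ccc(NCC2CCCC2)cc1Cl)c1cc(Cl)ccc1O`: 21500 nM
- Compound 2 `O=C(Nc1ccc(NCc2cccc(Br)n2)cc1Cl)c1cc(Cl)ccc1O`: 92300 nM

Compound 2 stands highest of the two at 92300 nM, which on this read-out means lower toxicity in this test. Compound 3 `CC(C)(CCO)Nc1ccc(NC(=O)c2cc(Cl)ccc2O)c(Cl)c1` keeps the shared core and differs from compound 2 only in one group: 3-hydroxy-1,1-dimethylpropyl in place of (6-bromopyridin-2-yl)methyl on a nitrogen on an aromatic ring. In words, 3-hydroxy-1,1-dimethylpropyl comes in place of (6-bromopyridin-2-yl)methyl on a nitrogen on an aromatic ring.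

Going by the values given here, only one measured step bears on this change: a 4.3-fold higher number from compound 1 to compound 2 (0.63 log units; beyond the scatter). There, 6-bromopyridin-2-yl took the place of cyclopentyl. Compound 3 gives up that aromatic ring, and like the cyclopentyl of compound 1, its new group has none. Part of that step may therefore be expected to reverse, giving a lower number in this assay. Among the compounds with values here, the evidence is thin, though, as it rests on a single step and no measured compound carries the 3-hydroxy-1,1-dimethylpropyl group. The expected change is a 2.2-fold lower number from compound 2 to compound 3 (0.34 log units; beyond the scatter), a modest estimated step. For compound 3 the estimated value is 42000 nM, with an expected range from 15000 nM to 100000 nM.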

Compound 3, half-maximal cytotoxic concentration: 170000 nM
For compound 3 the middle estimate is 4.0-fold (0.61 log units) below the measured one, and the stated range ends below it.
By their numbers in this assay, from the lowest: compound 1; then compounds 2 and 3 (each within the scatter of the next).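

The aromatic ring in this arm turns out not to be required for a high number in this assay: 3-hydroxy-1,1-dimethylpropyl has no ring, yet the change reads as a 1.8-fold higher number from compound 2 to compound 3 (0.27 log units; within the scatter), so these two compounds cannot be told apart here. Going by these compounds alone, the single earlier step suggested that losing the aromatic ring might pull the number back towards that of compound 1, but two ring-free arms now differ clearly, with a 7.9-fold higher number from compound 1 to compound 3 (0.90 log units; beyond the scatter). The absence of an aromatic ring therefore does not by itself set the number at this nitrogen, and which other feature of the arm matters remains to be found.

No supporting measurement is available to explain these differences. As far as these compounds go, the new arm differs from cyclopentylmethyl in several ways at once, so the roles of its hydroxy group and its two methyl groups stay open, and the same chain with an amine or a carboxylic acid in place of the hydroxy group, or a longer chain, could help to separate them.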